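Amino in place of dimethylamino, compound 3 to compound 4

The compounds below may be only part of what the source reports. "The series", "measured", "known", "first", "only" and "open" are said of these compounds alone.

In an ADME assay on Vero cells (Chlorocebus sabaeus) for cytotoxicity, with a stated time of 5 days (a higher number here means a weaker inhibitor, a lower number a stronger inhibitor), compound 1 (`C=CCNc1ncnc2c1ncn2[C@H]1C[C@H](N=[N+]=[N-])[C@@H](CO)O1`) gives > 100000 nM as a limit and not a number. Compound 2 (`CN(C)c1nc(N)nc2c1ncn2[C@H]1C[C@H](N=[N+]=[N-])[C@@H](CO)O1`) gives > 100000 nM as a limit too. Compound 3 (`CN(C)c1nc(Cl)nc2c1ncn2[C@H]1C[C@H](N=[N+]=[N-])[C@@H](CO)O1`) likewise gives > 100000 nM as a limit, so it has no number of its own. Among the compounds with values here, the series so far offers only the limit of > 100000 nM in this assay, at which 3 of the 3 values shown sit, and no measured value.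

Compound 4 (`[N-]=[N+]=N[C@H]1C[C@H](n2cnc3c(N)nc(Cl)nc32)O[C@@H]1CO`) keeps the chloro group of compound 3 and carries amino in place of dimethylamino on an aromatic carbon on the shared core. Within the data shown here, no measured step covers this exchange. Among the measured compounds shown here, the one measured step is a step that the two limits leave unreadable from compound 2 to compound 3 and so gives no size to carry over.

With compound 3 resting at > 100000 nM as a limit, no readable step is expected, and the data support no direction. The estimated change is a number no higher from compound 3 to compound 4 (the limit leaves the size open) in this assay and should not be read as a measured difference. A number under the limit cannot be excluded, so the expected range stays wide on the stronger side. For compound 4 the estimate is 100000 nM with an expected range from 30000 nM to 200000 nM and a report as a limit is the likeliest outcome.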

Compound 4, half-maximal inhibitory concentration: > 100000 nM
Compound 4: no number, only a limit (the forecaster's own chance of this, stated with the estimate: 70%); the middle value lies on the limit itself.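

In this assay compound 4 gives > 100000 nM, a limit and not a number. Compound 3 also rests on a limit, so the exchange of dimethylamino for amino between compound 3 and compound 4 yields no readable step. The compounds shown leave open how any exchange on the shared core moves this read-out, with every value resting on one limit: the limit of > 100000 nM in this assay, at which 4 of the 4 values shown sit.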